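Chain extension at the hydroxycarbamoyl end of compound 3

The compounds below may be only part of what the source reports. "The series", "measured", "known", "first", "only" and "open" are said of these compounds alone.

Three compounds share a core carrying a saturated chain from an aromatic nitrogen, each read in a functional assay on HCT-116 cells (Homo sapiens) for inhibition, read by MTT assay, with a stated time of 72 h; on this read-out lower numbers stand for stronger inhibition and higher numbers for weaker inhibition. Compound 1 `CNC(=O)CCCCCCCn1nc(-c2ccc3oc(N)nc3c2)c2c(N)ncnc21` gives 3150 nM. Among the measured compounds shown here, compound 2 `Nc1nc2cc(-c3nn(CCCCCC(=O)NO)c4ncnc(N)c34)ccc2o1` gives 21500 nM, and the single measured step, a 6.8-fold higher number from compound 1 to compound 2 (0.83 log units; beyond the scatter), exchanges the chain end and shortens the chain at once. Compound 3 `Nc1ncnc2c1c(-c1cnc3[nH]ccc3c1)nn2CCCCCCC(=O)NO` gives 9860 nM, the second highest of the three numbers: compound 2 sits higher and compound 1 lower, both beyond the scatter.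

Compound 4 `Nc1ncnc2c1c(-c1cnc3[nH]ccc3c1)nn2CCCCCCCCC(=O)NO` is not yet measured. It differs from compound 3 by 2-(hydroxycarbamoyl)ethyl in place of hydroxycarbamoyl on a saturated chain carbon, six bonds along the chain from an aromatic nitrogen. For the measured compounds named here, no measured step keeps the hydroxycarbamoyl end and alters only the chain, so the measured step bears on it loosely at best; it shows that a longer chain with a different end gave the lower number. A small lowering of the number, or no change beyond the scatter, is therefore expected for compound 4, as a 1.8-fold lower number from compound 3 to compound 4 (0.25 log units; within the scatter). The estimate for compound 4 in this assay is 5500 nM, within 1800 nM to 16000 nM.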

Compound 4, half-maximal inhibitory concentration: 5460 nM
The estimate for compound 4 lay 1.0-fold (0.00 log units) above the measured number; low and high end bracket the measured number.
By their numbers in this assay, from the lowest: compounds 1, 4 and 3 (each within the scatter of the next, the first and the last beyond it); then compound 2.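

Among the compounds shown here, with the hydroxycarbamoyl end held constant, the step in this assay, a 1.8-fold lower number from compound 3 to compound 4 (0.26 log units; within the scatter), is the first reading of the chain alone. The earlier step exchanged the chain end as well and could not give this reading. At this position, six bonds along the chain from an aromatic nitrogen, 2-(hydroxycarbamoyl)ethyl in place of hydroxycarbamoyl therefore leaves the two numbers within the scatter of each other, and this extension does not separate them in this read-out. No supporting data bear on why the chain extension has this outcome.

Open, going by these compounds, is whether a longer chain than that of compound 4, or a carboxylic acid in place of the hydroxycarbamoyl end, would give a number beyond the scatter of compound 4. Also open, on these data alone, is whether the same extension would read alike on the core of compound 2.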